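Series notes: acetamido variant of compound 2

The compounds below may be only part of what the source reports. "The series", "measured", "known", "first", "only" and "open" are said of these compounds alone.

The series shares one core, carried by compound 1 `C#CCOc1ccc2oc(=O)ccc2c1`, compound 2 `O=c1ccc2cc(OCc3cn(-c4ccccc4)nn3)ccc2o1`, compound 3 `O=c1ccc2cc(OCc3cn(-c4cccc(CO)c4)nn3)ccc2o1` and the not yet measured compound 4 `CC(=O)Nc1ccc(-n2cc(COc3ccc4oc(=O)ccc4c3)nn2)cc1`. Among the measured compounds shown here, only one number exists so far. In a functional assay on HL-60 cells (Homo sapiens) for cytotoxicity, read by MTT assay, with a stated time of 48 h (a higher number here means a weaker inhibitor, a lower number a stronger inhibitor), compound 2 gives 41600 nM. In this assay compound 1 gives "not determined" (no result reported) and compound 3 gives "not determined" (no result reported), so compound 2 stands as the single reference point, and the two other entries allow no comparison. Compound 4 differs from compound 2 in one place: acetamido in place of hydrogen on an aromatic carbon, para to a large group on the six-membered aromatic ring of carbon only. For the measured compounds named here, no step between two measured compounds is available, so nothing itself shows how such a change moves the read-out. The working expectation for the step from compound 2 to compound 4 in this assay is a 1.2-fold lower number from compound 2 to compound 4 (0.08 log units; within the scatter), a shift not beyond the scatter of repeated measurements, with no direction favoured. Compound 4 is accordingly estimated at 35000 nM in this assay, with a range from 12000 nM to 100000 nM. Since compound 2 gives 41600 nM, compound 4 is expected to read in the same weak region of this assay.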

Compound 4, half-maximal inhibitory concentration: 40400 nM
The estimate for compound 4 lay 1.2-fold (0.06 log units) below the measured number; the measured number falls inside the stated range.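

In this assay the series now has its first readable step: acetamido in place of hydrogen on an aromatic carbon, para to a large group on the six-membered aromatic ring of carbon only, gives a 1.0-fold lower number from compound 2 to compound 4 (0.01 log units; within the scatter) and so lies within the scatter. This place on the ring therefore accepts a substituent carrying a hydrogen-bond donor, a hydrogen-bond acceptor and a double bond outside aromatic rings, and compound 2 at 41600 nM and compound 4 at 40400 nM cannot be told apart in this read-out. No measurement at hand bears on why the two compounds read alike.

As far as these compounds go, whether this place stays as flat for other groups remains open, since a single substituent sets no pattern, and an amine, a carboxylic acid or a longer chain could still separate from compound 2 in this assay or could read the same. Steps involving compound 1 and compound 3 cannot be read, so the effect of changes elsewhere on the aromatic ring, and of the aromatic ring itself, stays unknown in this series.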